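One group exchanged on compound 2

The source may report more compounds than this note shows. Statements on the series, on what has been measured and on what is new or still open speak of the compounds shown alone.

Compound 1 `CC(O)(CSc1ccc(S(F)(F)(F)(F)F)cc1)C(=O)Nc1cccc(S(F)(F)(F)(F)F)c1` gives 24100 nM
Compound 2 `CC(O)(CS(=O)(=O)c1ccc(S(F)(F)(F)(F)F)cc1)C(=O)Nc1cccc(S(F)(F)(F)(F)F)c1` gives 17200 nM

Both numbers come from a functional assay on VCaP cells (Homo sapiens) for antiproliferative activity, read by propidium iodide staining, with a stated time of 96 h (on this read-out lower numbers stand for stronger inhibition and higher numbers for weaker inhibition), and lie within the usual scatter of each other, so compound 2 does not stand apart from compound 1. Compound 3 `CC(O)(CS(=O)(=O)c1ccc(OC(F)(F)F)cc1)C(=O)Nc1cccc(S(F)(F)(F)(F)F)c1` differs from compound 2 at one place, on an aromatic carbon (a group of 5 heavy atoms (1 carbon, 1 oxygen, 3 fluorine; no ring) in place of a group of 6 heavy atoms (5 fluorine, 1 sulfur; no ring), on an aromatic carbon), where trifluoromethoxy enters. Within the data shown here, no measured pair shows such an exchange, so no change beyond the scatter is expected in this assay. The expected 1.1-fold lower number from compound 2 to compound 3 (0.06 log units; within the scatter) is small. The estimate starts from compound 2 at 17200 nM as its anchor. For compound 3 the estimated value is 15000 nM with 6000 nM to 35000 nM as the expected range.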

Compound 3, half-maximal inhibitory concentration: 15100 nM
For compound 3 the middle estimate is 1.0-fold (0.00 log units) below the measured one; the measured number falls inside the stated range.
By their numbers in this assay, from the lowest: compounds 3, 2 and 1 (each within the scatter of the next).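

On this aromatic carbon, putting trifluoromethoxy in place of the group of one sulfur and five fluorine atoms gives a 1.1-fold lower number from compound 2 to compound 3 (0.06 log units; within the scatter) in this assay. This position therefore accepts the exchange, and compounds 2 and 3 cannot be told apart here, even though the entering group counts one hydrogen-bond acceptor and the leaving group none. Nothing available explains why the two groups read alike. Going by these compounds, whether an amine or a carboxylic acid on this carbon would shift the number stays open.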